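Swapping One Group on the Carbonyl of Compound 1

This account rests on a few compounds, and the source may have more. Where it says the series, first, only, none or still open, it means among the compounds named here.

- compound 1 `COc1ccc(CN(C(=O)C=C(C)C)c2cc(OC)c(OC)c(OC)c2)cc1O`: 280 nM
- compound 2 `COc1cc(NCc2cccc(O)c2)cc(OC)c1OC`: 71300 nM

For the measured compounds named here, in a functional assay on KYSE-450 cells (Homo sapiens) for inhibition, read by MTT assay, with a stated time of 48 h (on this read-out higher numbers stand for weaker inhibition and lower numbers for stronger inhibition), compound 1 gives 280 nM, the lower of the two numbers measured so far. Compound 2 gives 71300 nM, and that gap lies far beyond the usual scatter of repeat measurements.

Compound 3 `COc1ccc(CN(C(=O)CCl)c2cc(OC)c(OC)c(OC)c2)cc1O` has not yet been measured. Compared with compound 1, it carries chloromethyl in place of 2-methylprop-1-en-1-yl on a carbonyl carbon. The rest of the structure stays the same.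

Going by the values given here, no measured pair of compounds shows this kind of change, so the expectation is loose. Compound 3 is expected to stay closer to compound 1 than to compound 2 in this assay. A small move toward a higher number, meaning weaker inhibition, seems most likely, and it may not exceed the scatter. The expected step is a 1.6-fold higher number from compound 1 to compound 3 (0.21 log units; within the scatter). The estimated value for compound 3 is 450 nM, with an expected range from 90 nM to 2500 nM.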

Compound 3, half-maximal inhibitory concentration: 210 nM
Estimate against measurement, compound 3: 2.1-fold (0.33 log units) above; the range from low to high includes it.
By their numbers in this assay, from the lowest: compounds 3 and 1 (each within the scatter of the next); then compound 2.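

In this assay, putting chloromethyl in place of 2-methylprop-1-en-1-yl on a carbonyl carbon gives a 1.3-fold lower number from compound 1 to compound 3 (0.12 log units; within the scatter), so the two compounds cannot be told apart on this read-out. For the compounds shown here, this is the first step in the set that changes only one place, and it shows that this position can take quite different groups without a change beyond the scatter: the incoming group has fewer heavy atoms, has no double bond and brings in a chlorine. Nothing measured here explains why these two groups read alike.

On these data alone, one pair cannot show how far this tolerance extends, so it remains open whether an amine, a carboxylic acid or a longer chain on the same carbonyl carbon would give a similar number or a very different one. The step also swaps the whole group at once, which leaves the part played by the chlorine unresolved, and a plain methyl group in the same place would help to separate the chlorine from the rest of the change.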